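A few compounds are considered here, and "the series" means these few. Any claim that something is new, unique, unknown or untested is made for them only; others in the source may bear on it.

Working notes on the series. The shared core of compound 1 `COc1cc(C2=NN(C(C)=O)C(c3ccc(Cl)cc3)C2)cc(OC)c1OC` carries two aryl groups on a five-membered ring with an acetyl group on nitrogen. Among the compounds with values here, in a functional assay on B16 cells (Mus musculus) for cytotoxicity, read by MTT assay, with a stated time of 72 h (a higher number here means a weaker inhibitor, a lower number a stronger inhibitor), compound 1 gives 35000 nM, the lower of the two numbers so far, while compound 2 `COc1cc(OC)c(C2CC(c3cc(OC)ccc3OC)=NN2C(C)=O)c(OC)c1` gives 69000 nM; the two values lie within the scatter of each other, so no order between them is claimed. Compound 3 `COc1ccc(OC)c(C2CC(c3cc(OC)c(OC)c(OC)c3)=NN2C(C)=O)c1` has not yet been measured. It differs from compound 1 in one place: 2,5-dimethoxyphenyl in place of 4-chlorophenyl on a saturated ring carbon. Within the data shown here, no measured pair shows this change, and both measured numbers sit in the same weak region, so no step beyond the scatter is expected in either direction. The value for compound 3 is therefore estimated at 50000 nM, with a range from 20000 nM to 120000 nM. This estimate implies a step from compound 1 to compound 3 of a 1.4-fold higher number from compound 1 to compound 3 (0.15 log units; within the scatter), which is expected to stay within the scatter.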

Compound 3, half-maximal inhibitory concentration: > 100000 nM
Compound 3 ended at the assay's limit; the forecaster's own chance of this, stated with the estimate: 15%; middle value at least 2.0-fold (0.30 log units) away from the limit.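

In this assay compound 3 gives > 100000 nM, which is a limit of the assay and not a number. Within the data shown here, on a saturated ring carbon, 2,5-dimethoxyphenyl in place of 4-chlorophenyl gives an at least 2.8-fold higher number from compound 1 to compound 3 (0.45 log units; beyond the scatter), the first step that can be read, and it shows that this position is not indifferent to the aryl group it carries. The size of that step remains a bound and not a measured distance: the limit of > 100000 nM in this assay, at which 1 of the 3 values shown sits.

Open, from the compounds shown here alone, is which part of the change carries the step, the loss of the chlorine or the entry of the methoxy groups. Also open, going by these compounds, is whether a plain phenyl, or a phenyl bearing an amine, on this saturated ring carbon would fall nearer compound 1 or compound 3.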